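Moving the Nitro Group Along a Short Chain

This account rests on a few compounds, and the source may have more. Where it says the series, first, only, none or still open, it means among the compounds named here.

Measured so far in a physicochemical assay for lipophilicity; a lower number here means a more polar compound, a higher number a more lipophilic compound:
compound 1, `CC(OCn1cc[n+](C)c1/C=N/O)C(C)S(C)(=O)=O`: -2.09; -2.79 (2 entries)
compound 2, `CC(OCn1cc[n+](C)c1/C=N/O)C(C)(C)[N+](=O)[O-]`: -1.75

Both compounds share a charged core carrying an oxime, joined through an ether oxygen to a short saturated chain. Compound 1 has been run twice in this assay, and the two readings the several entries of compound 1 in this assay, -2.09; -2.79 (2 entries) show how much such values can wander. Among the measured compounds shown here, compound 2 carries a nitro group on a branched chain and gives the single value quoted for it, -1.75, with one further entry that yielded no number.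

Compound 3, `CC(CCC[N+](=O)[O-])OCn1cc[n+](C)c1/C=N/O`, has not yet been measured. It is built from the same atoms as compound 2, joined in a different way: 3-nitropropyl in place of 1-methyl-1-nitroethyl on a saturated chain carbon bound to an oxygen on a saturated carbon and a saturated chain carbon. Nothing in the chain is added or taken away, and no charge or hydrogen-bond donor is gained or lost. Without a measured step of this kind to lean on, the expectation is that the step from compound 2 to compound 3 in this assay, a number 0.05 log units higher from compound 2 to compound 3 (within the scatter), stays within the usual scatter, with no clear direction. Compound 3 is therefore expected to give about -1.7, somewhere between -2.3 and -1.1.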

Compound 3, distribution coefficient: -2.11
Beside the measured number, compound 3's estimate is 0.41 log units above it; low and high end bracket the measured number.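

Among the compounds shown here, compounds 2 and 3 are the first pair here that differ in only one place, so they give the first reading of a change at this saturated chain carbon. In this assay, replacing 1-methyl-1-nitroethyl with 3-nitropropyl gives a number 0.36 log units lower from compound 2 to compound 3 (beyond the scatter), which shows that the reading at this position depends on how the atoms are joined, even though the atom count, the double bond count and the hydrogen-bond counts of the group stay the same. The step is still only modest and rests on a single number for each compound, and repeat runs in this series can lie well apart, so its size should be treated with some caution: the several entries of compound 1 in this assay, -2.09; -2.79 (2 entries)

This one pair cannot separate the loss of branching from the shift of the nitro group along the chain, as both change together in going to 3-nitropropyl. Going by these compounds, how a longer chain such as 4-nitrobutyl, or a nitrile in place of the nitro group, would read in this assay at this same place remains open.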